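This account rests on a few compounds, and the source may have more. Where it says the series, first, only, none or still open, it means among the compounds named here.

Working notes on the series. For the measured compounds named here, compound 2 `N#Cc1ccc(-c2cnc3[nH]cc(-c4nnc(-c5ccc(Cl)cc5)o4)c(=O)c3c2)cc1` has the highest of the two numbers so far in a functional assay on HepG2 cells (Homo sapiens) for inhibition, read by MTT assay, with a stated time of 24 h, tested at 5 uM (a higher number here means more inhibition of growth at the concentration tested, a lower number less inhibition of growth), where compound 2 gives 11.5%; the nearest neighbour is compound 1 `CS(=O)(=O)c1ccc(-c2cnc3[nH]cc(-c4nnc(-c5ccc(Cl)cc5)o4)c(=O)c3c2)cc1`, and in this assay compound 1 gives 11.3%. Going by the values given here, the only measured step, a number 0.2 percentage points higher from compound 1 to compound 2 (within the scatter), swaps one substituent for another at the same position and lies within the scatter, so neither compound can be called the more active.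

The next compound, compound 3 `O=c1c(-c2nnc(-c3ccc(Cl)cc3)o2)c[nH]c2ncc(-c3ccccc3)cc12`, is reached from compound 2 by a change of hydrogen in place of cyano on an aromatic carbon. The step from compound 1 to compound 2 bears on it, being a change at the same aromatic carbon, para to a large group; its size, a number 0.2 percentage points higher from compound 1 to compound 2 (within the scatter), gave no movement beyond the scatter. Two substituents at this position have therefore left the growth inhibition unchanged, and a bare hydrogen there is expected to do the same. The expected step from compound 2 to compound 3 in this assay is a number 0.5 percentage points lower from compound 2 to compound 3 (within the scatter), within the scatter. The estimate for compound 3 in this assay is 11%, in the range 2% to 22%.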

Compound 3, percent growth inhibition at one concentration: 5.1%
Compound 3: middle estimate off by 5.9 percentage points, on the high side, within the range that was stated.
By their numbers in this assay, from the lowest: compounds 3, 1 and 2 (each within the scatter of the next).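

In this assay, hydrogen on this aromatic carbon, para to a large group, adds the case with no substituent to the two substituted cases, and both steps to it, a number 6.4 percentage points lower from compound 2 to compound 3 (within the scatter) and a number 6.2 percentage points lower from compound 1 to compound 3 (within the scatter), stay within the scatter. Across compounds 1, 2 and 3, therefore, neither 4-cyanophenyl, its methylsulfonyl counterpart nor phenyl can be separated from the others, so no order can be given among the three and neither substituent can be said to contribute to growth inhibition beyond what the phenyl compound shows. The series gives no explanation for these numbers, and none can be offered for any part of this reading.

Open, going by these compounds, is whether any group at this carbon moves the reading beyond the scatter, for example an amine, a carboxylic acid or a longer chain such as a butoxy group. Also open, on these data alone, is whether a change elsewhere on the shared core, such as replacing the chlorine on the other aromatic ring with a methoxy group, would separate compounds in this assay where these three substituents do not.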